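The source may report more compounds than this note shows. Statements on the series, on what has been measured and on what is new or still open speak of the compounds shown alone.

Measured so far in a functional assay on microsomes from liver (Rattus norvegicus, strain Wistar) for inhibition, with a stated time of 15 min; a higher number here means a weaker inhibitor, a lower number a stronger inhibitor:
- compound 1 `COc1cc(C2CC(c3cc4ccccc4o3)=NN2C(=O)Nc2ccccc2)ccc1O` gives 116000000 nM
- compound 2 `COc1cc(C2CC(c3cc4ccccc4o3)=NN2C(=O)Nc2ccc([N+](=O)[O-])cc2)ccc1O` gives 113000000 nM

Compound 2 stands level with compound 1: the two numbers lie within the scatter of each other (a 1.0-fold lower number from compound 1 to compound 2 (0.01 log units; within the scatter)). That step, nitro in place of hydrogen on an aromatic carbon, is the only measured one that bears on the next compound. Compound 3 `COc1cc(NC(=O)N2N=C(c3cc4ccccc4o3)CC2c2ccc(O)c(OC)c2)ccc1O` keeps the core of compound 2 and differs by 4-hydroxy-3-methoxyphenyl in place of 4-nitrophenyl on an amide-type nitrogen. Among the compounds with values here, no measured compound carries hydroxy or methoxy on that ring, so one step within the scatter is thin support. Even so, no step beyond the scatter is expected in this assay, on the evidence of the one measured step (a 1.0-fold lower number from compound 1 to compound 2 (0.01 log units; within the scatter)). The expected step stays small (a 1.1-fold lower number from compound 2 to compound 3 (0.05 log units; within the scatter)). For compound 3 the estimated value is 100000000 nM, with an expected range kept wide (45000000 nM to 180000000 nM).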

Compound 3, half-maximal inhibitory concentration: 12000000 nM
Compound 3: middle estimate off by 8.3-fold (0.92 log units), on the high side; measured number outside the range, below it.
By their numbers in this assay, from the lowest: compound 3; then compounds 2 and 1 (each within the scatter of the next).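

Notes on the aryl group on the amide-type nitrogen, read in this assay: this position does respond to substitution, with 4-hydroxy-3-methoxyphenyl in place of 4-nitrophenyl giving a 9.4-fold lower number from compound 2 to compound 3 (0.97 log units; beyond the scatter) and the same group in place of phenyl giving a 9.7-fold lower number from compound 1 to compound 3 (0.99 log units; beyond the scatter). Within the data shown here, the only earlier step, a 1.0-fold lower number from compound 1 to compound 2 (0.01 log units; within the scatter), stayed within the scatter, so it speaks for nitro alone and not for the position as a whole; compound 3 is now the one compound here with a number beyond the scatter of both others, and both steps to it have about the same size whichever of the two earlier groups leaves. No measured evidence on the cause of this step is at hand.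

The entering group brings hydroxy and methoxy together, so these compounds cannot tell whether one of the two carries the step, or whether it takes both, as hydroxy alone or methoxy alone on that ring would show. Also open, from the compounds shown here alone, is how far the step extends to other groups on that ring, such as an amine or a carboxylic acid, and whether it holds on any core other than the shared one.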